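A few compounds are considered here, and "the series" means these few. Any claim that something is new, unique, unknown or untested is made for them only; others in the source may bear on it.

Measured compounds in a functional assay on MCF7 cells (Homo sapiens) for cytotoxicity, read by MTT assay, with a stated time of 72 h; a higher number here means a weaker inhibitor, a lower number a stronger inhibitor:
Compound 1 `FC(F)(F)c1ccc(CSc2nc(Nc3ccccc3)c3ccccc3n2)cc1` gives 44000 nM.
Compound 2 `FC(F)(F)c1ccc(CSc2nc(Nc3ccccc3Cl)c3ccccc3n2)cc1` gives > 50000 nM, which is a limit of the assay, not a number.
Compound 3 `COc1cc(Nc2nc(SCc3ccc(C(F)(F)F)cc3)nc3ccccc23)cc(OC)c1` gives 6990 nM.

Compound 2 therefore stands at the limit (the limit of > 50000 nM in this assay, at which 1 of the 3 values shown sits), and the step of an at least 1.1-fold higher number from compound 1 to compound 2 (0.05 log units; that floor lies within the scatter) lies within the scatter. Compound 4 `COc1ccc(Nc2nc(SCc3ccc(C(F)(F)F)cc3)nc3ccccc23)cc1OC` differs from compound 2 in one place: 3,4-dimethoxyphenyl in place of 2-chlorophenyl on a nitrogen on an aromatic ring. Going by the values given here, the steps that bear on this are an at least 7.1-fold lower number from compound 2 to compound 3 (0.85 log units; beyond the scatter) and a 6.3-fold lower number from compound 1 to compound 3 (0.80 log units; beyond the scatter), each a modest move to a lower number on putting a dimethoxyphenyl on that nitrogen. A step of comparable size, to a lower number, is therefore expected here, estimated as an at least 5.0-fold lower number from compound 2 to compound 4 (0.69 log units; beyond the scatter). Compound 4 is expected to give 10000 nM, with a range from 3000 nM to 35000 nM.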

Compound 4, half-maximal inhibitory concentration: > 50000 nM
Compound 4: a limit, no number; the forecaster's own chance of this, stated with the estimate: 15%; middle value at least 5.0-fold (0.69 log units) away from the limit.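

In this assay compound 4 gives > 50000 nM, a limit of the assay and not a number, so a dimethoxyphenyl on this nitrogen does not in itself go with a lower number: the limit of > 50000 nM in this assay, at which 2 of the 4 values shown sit. The change to 3,4-dimethoxyphenyl from 3,5-dimethoxyphenyl gives an at least 7.1-fold higher number from compound 3 to compound 4 (0.85 log units; beyond the scatter), so the arrangement of the two methoxy groups matters in this pair. From phenyl, the same group gives an at least 1.1-fold higher number from compound 1 to compound 4 (0.05 log units; that floor lies within the scatter), while the step between the two limits cannot be read.

On these data alone, how far compound 2 and compound 4 lie past the limit remains unknown. Also open, as far as these compounds go, is whether the lower number of compound 3 needs both methoxy groups, or whether a phenyl with one methoxy group, or with two hydroxy groups instead, would match it.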